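This account rests on a few compounds, and the source may have more. Where it says the series, first, only, none or still open, it means among the compounds named here.

Compound 1 `O=C(Nc1ccc(Oc2ccnc3[nH]ccc23)c(F)c1)c1ccc(-c2ccccc2)cn1` and compound 2 `Cc1ccc(-c2ccc(C(=O)Nc3ccc(Oc4ccnc5[nH]ccc45)c(F)c3)nc2)cc1` share one core and differ in a single group. In a functional assay on MCF7 cells (Homo sapiens) for cytotoxicity, read by MTT assay, with a stated time of 72 h (a lower number here means a stronger inhibitor, a higher number a weaker inhibitor), compound 1 gives 4390 nM, and compound 2 gives 8020 nM. The step of a 1.8-fold higher number from compound 1 to compound 2 (0.26 log units; within the scatter) lies within the scatter of repeated measurements. Among the compounds with values here, compound 2 therefore holds the higher of the two numbers measured so far, but its only neighbour, compound 1, sits within the scatter of it, so no order between the two is claimed.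

Compound 3 `COc1ccc(-c2ccc(C(=O)Nc3ccc(Oc4ccnc5[nH]ccc45)c(F)c3)nc2)cc1` has not yet been measured in this assay. It differs from compound 2 by methoxy in place of methyl on an aromatic carbon. Within the data shown here, no measured pair shows a methoxy in place of a methyl, so nothing bears on this change directly; the only measured step, a 1.8-fold higher number from compound 1 to compound 2 (0.26 log units; within the scatter), concerns a methyl in place of hydrogen and stayed within the scatter. On this basis the change is expected to leave the number where it is, with no step beyond the scatter in either direction, and the expected step of a 1.1-fold lower number from compound 2 to compound 3 (0.06 log units; within the scatter) is correspondingly small. Compound 3 is estimated at 7000 nM, with a range from 2500 nM to 20000 nM.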

Compound 3, half-maximal inhibitory concentration: 10100 nM
For compound 3 the middle estimate is 1.4-fold (0.16 log units) below the measured one; the range from low to high includes it.
By their numbers in this assay, from the lowest: compounds 1, 2 and 3 (each within the scatter of the next, the first and the last beyond it).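

The change from 4-methylphenyl to 4-methoxyphenyl adds an oxygen and a hydrogen-bond acceptor, yet in this assay it gives only a small step (a 1.3-fold higher number from compound 2 to compound 3 (0.10 log units; within the scatter)), so compound 2 and compound 3 cannot be ordered. Within the data shown here, the position is not entirely silent, however: methoxy in place of hydrogen gives the first step in this short series to clear the scatter (a 2.3-fold higher number from compound 1 to compound 3 (0.36 log units; beyond the scatter)), although that step is modest and the methyl step (a 1.8-fold higher number from compound 1 to compound 2 (0.26 log units; within the scatter)) does not clear it. Methoxy thus separates from hydrogen where methyl does not, even though methoxy and methyl cannot themselves be told apart, and nothing available here accounts for this.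

On these data alone, what an amine, a carboxylic acid or a longer chain would do at this aromatic carbon remains open. The compounds shown also leave open whether the modest separation between compound 1 and compound 3 would hold with any other group on the shared core.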